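A Double-Bond Geometry Question in a Weakly Cytotoxic Series

The source may report more compounds than this note shows. Statements on the series, on what has been measured and on what is new or still open speak of the compounds shown alone.

In a functional assay on MCF7 cells (Homo sapiens) for cytotoxicity (on this read-out lower numbers stand for stronger inhibition and higher numbers for weaker inhibition), compound 1 (`COc1c(O)cc2c3c1C[C@@H](C)C[C@H](OC)[C@H](O3)[C@@H](C)/C=C(\C)[C@H](OC(N)=O)[C@@H](OC)C[C@@H](O)/C=C(\C)C(=O)N2`) returns > 100000 nM as a limit only. Compound 2 (`COc1c(O)cc2c3c1C[C@@H](C)C[C@H](OC)[C@H](O3)[C@@H](C)/C=C(\C)[C@H](OC(N)=O)[C@@H](OC)CC/C=C(\C)C(=O)N2`) gives 70000 nM as a measured number, and the exchange of hydroxy for hydrogen amounts to an at least 1.4-fold lower number from compound 1 to compound 2 (0.15 log units; that floor lies within the scatter) in this single-place comparison. Compound 3 (`COc1c(O)cc2c3c1C[C@@H](C)C[C@H](OC)[C@H](O3)[C@@H](C)/C=C(\C)[C@H](OC(N)=O)[C@@H](OC)/C=C\C=C(/C)C(=O)N2`) gives 20000 nM in this assay and so stands lowest of the measured numbers, beyond the scatter from compound 2. Among the compounds with values here, compound 4 (`COc1c(O)cc2c3c1C[C@@H](C)C[C@H](OC)[C@H](O3)[C@@H](C)/C=C(\C)[C@H](OC(N)=O)[C@@H](OC)/C=C/C=C(\C)C(=O)N2`) differs only in geometry (the two compounds have the same atoms and bonds and differ only in configuration as drawn: 1 of 9 stereo elements differ; a double bond is drawn Z in compound 3 and E in compound 4) and no measured step concerns such a change, so an at least 1.4-fold lower number from compound 1 to compound 2 (0.15 log units; that floor lies within the scatter) offers no size to carry over. The expected step is a 1.3-fold lower number from compound 3 to compound 4 (0.12 log units; within the scatter) and no shift beyond the scatter is expected. For compound 4 an expected 15000 nM is estimated, with 3000 nM to 70000 nM as the expected range.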

Compound 4, half-maximal inhibitory concentration: 36000 nM
Compound 4: the middle estimate sits 2.4-fold (0.38 log units) below what was measured; measured number inside the range.
By their numbers in this assay, from the lowest: compounds 3, 4 and 2 (each within the scatter of the next, the first and the last beyond it). At a limit, above all of these: compound 1.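

Setting the double bond E rather than Z gives a 1.8-fold higher number from compound 3 to compound 4 (0.26 log units; within the scatter), so in this assay the geometry of this double bond does not separate the two compounds. Unlike the step that starts from the limit of compound 1, this step has a measured number at both ends. It also speaks to geometry alone, for one reason: the fact that compounds 3 and 4 differ only in the configuration as drawn

The compounds shown leave open how an amine or a carboxylic acid in place of the hydroxy of compound 1 would read in this assay. They also leave open whether any change at this place reaches numbers well under those of compound 3 and compound 4.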